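Swapping bromo for methyl on a cinnamamide pyrazole

The compounds below may be only part of what the source reports. "The series", "measured", "known", "first", "only" and "open" are said of these compounds alone.

Compounds measured so far:
compound 1, `Cc1ccc(-c2cc(NC(=O)/C=C/c3ccc(Cl)cc3)n[nH]2)cc1`, 1520 nM
compound 2, `O=C(/C=C/c1ccc(Br)cc1)Nc1cc(-c2ccccc2)[nH]n1`, 1380 nM
compound 3, `O=C(/C=C/c1ccc(Cl)cc1)Nc1cc(-c2ccc(Br)cc2)[nH]n1`, 1080 nM

All three were tested in a functional assay on B16-F10 cells (Mus musculus) for antiproliferative activity, read by MTT assay, with a stated time of 48 h; a lower number here means a stronger inhibitor, a higher number a weaker inhibitor. Compound 3 gives 1080 nM, compound 1 gives 1520 nM, and compound 2 gives 1380 nM; these three numbers sit within the usual scatter of one another, so no order among them can be read.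

Compound 1 differs from compound 3 in one place: methyl in place of bromo on an aromatic carbon. That change brought a 1.4-fold higher number from compound 3 to compound 1 (0.15 log units; within the scatter), a shift that is within the scatter.

Compound 4, `Cc1ccc(/C=C/C(=O)Nc2cc(-c3ccccc3)[nH]n2)cc1`, has not yet been measured in this assay. It differs from compound 2 in one place: methyl in place of bromo on an aromatic carbon. The place lines for the two changes read the same word for word, so this is the same change as that from compound 3 to compound 1, made on a different core; the difference between the core of compound 2 and the core of compound 3 is not broken down here.

Resting on the one earlier example, the expected step is a 1.4-fold higher number from compound 2 to compound 4 (0.14 log units; within the scatter), of about the size seen from compound 3 to compound 1, because a 1.4-fold higher number from compound 3 to compound 1 (0.15 log units; within the scatter) stayed within the scatter. Compound 4 is therefore expected to give about 1900 nM, with a range from 900 nM to 4000 nM.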

Compound 4, half-maximal inhibitory concentration: 1680 nM
Beside the measured number, compound 4's estimate is 1.1-fold (0.05 log units) above it; low and high end bracket the measured number.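

In this assay, going from 4-bromophenyl to 4-methylphenyl gave a 1.2-fold higher number from compound 2 to compound 4 (0.09 log units; within the scatter), so on this second core the change again left the number within the usual scatter. Set side by side, the two examples of the change agree: the same change on two cores in this assay, a 1.4-fold higher number (0.15 log units; within the scatter) from compound 3 to compound 1 and a 1.2-fold higher number (0.09 log units; within the scatter) from compound 2 to compound 4, 1.2-fold (0.06 log units) apart, within the scatter of two such steps. This shows that, in these two pairs, bromo and methyl at this place cannot be told apart by this read-out, and that the change behaved alike on both cores; it does not show that the change has no effect at all, as a step within the scatter cannot separate a small real shift from the noise of repeated measurements, nor does it show that a third core would behave the same way, as two pairs are a very small sample.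

The compounds shown leave open whether any group at this place can move the number beyond the scatter, for example an amine, a carboxylic acid or a longer chain such as butyl. They also leave open whether bromo and methyl would stay this close on other cells or in a read-out other than the one used here.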